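A few compounds are considered here, and "the series" means these few. Any claim that something is new, unique, unknown or untested is made for them only; others in the source may bear on it.

In a functional assay on MCF7 cells (Homo sapiens) for inhibition, read by MTT assay, with a stated time of 72 h (on this read-out higher numbers stand for weaker inhibition and lower numbers for stronger inhibition), compound 1 (`COC(=O)NCCOc1ccc(Cl)cc1C(=O)N[C@H](C(=O)Nc1ccc([N+](=O)[O-])cc1Cl)C(C)C`) gives > 10000 nM, which is a limit. Compound 2 (`CC(C)[C@H](NC(=O)c1cc(Cl)ccc1OCCCNC(=O)OC(C)(C)C)C(=O)Nc1ccc([N+](=O)[O-])cc1Cl`) gives > 10000 nM, also a limit. Compound 3 (`CC(C)[C@H](NC(=O)c1cc(Cl)ccc1OCCCCNC(=O)OC(C)(C)C)C(=O)Nc1ccc([N+](=O)[O-])cc1Cl`) gives > 10000 nM, again a limit. Together these three compounds stand at the limit of > 10000 nM in this assay, at which 3 of the 3 values shown sit. Compound 4 (`CC(C)[C@H](NC(=O)c1cc(Cl)ccc1OCCCCN)C(=O)Nc1ccc([N+](=O)[O-])cc1Cl`) differs from compound 3 by hydrogen in place of tert-butoxycarbonyl on an amine nitrogen. The measured steps give no usable size: a step that the two limits leave unreadable from compound 1 to compound 2, a step that the two limits leave unreadable from compound 1 to compound 3 and a step that the two limits leave unreadable from compound 2 to compound 3 all leave the nitrogen capped. A modest move towards stronger inhibition in this assay is therefore expected only tentatively, and another reading at the limit remains quite possible. The expected change is an at least 1.4-fold lower number from compound 3 to compound 4 (0.15 log units; that floor lies within the scatter). For compound 4 the estimated value is 7000 nM, within an expected range of 1500 nM to 15000 nM.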

Compound 4, half-maximal inhibitory concentration: > 10000 nM
Compound 4: a limit, no number; the forecaster's own chance of this, stated with the estimate: 45%; at least 1.4-fold (0.15 log units) between middle value and limit.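

Compound 4, like compound 1, compound 2 and compound 3, gives only a limit in this assay, so no step among them can be read: the limit of > 10000 nM in this assay, at which 4 of the 4 values shown sit.

The compounds shown leave open how strongly any of them inhibits, and whether hydrogen in place of tert-butoxycarbonyl on the amine nitrogen changes that at all.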